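The compounds below may be only part of what the source reports. "The series", "measured", "known", "first", "only" and "open" are said of these compounds alone.

Measured compounds in an assay on COS-7 cells for inhibition of patatin-like phospholipase domain-containing protein 2 (Mus musculus), tested at 200 uM; on this read-out lower numbers stand for less inhibition and higher numbers for more inhibition at the one concentration tested (going by the name of the read-out):

compound 1 `CN(C)C(=O)Nc1cccc(-c2ccc(N(C)C)cc2)c1`: 98%
compound 2 `CN(C)c1ccc(-c2cccc(NC(=O)Oc3ccccc3)c2)cc1`: 75%

Compound 2 holds the lower of the two numbers recorded in this assay; its nearest neighbour is compound 1, whose number is higher by a margin beyond the scatter. Going by the values given here, the one step recorded between measured compounds is a number 23 percentage points lower from compound 1 to compound 2 (beyond the scatter), a modest loss on exchanging dimethylamino for phenoxy on the carbonyl carbon.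

Compound 3 `CN(C)c1ccc(-c2cccc(NC(=O)OCc3ccccc3)c2)cc1` is not yet measured. It differs from compound 2 in one place: benzyl in place of phenyl on an oxygen next to a carbonyl group. Among the compounds with values here, no measured pair shows this particular exchange; the step from compound 1 to compound 2 concerns the group on the carbonyl carbon, not what hangs on the oxygen, so it bears on compound 3 only in that the carbamate series has so far stayed within a narrow band. With nothing directly comparable, a change within the scatter is expected for a number 3 percentage points lower from compound 2 to compound 3 (within the scatter). Compound 3 is therefore estimated at 72% in this assay, with a range from 50% to 92%.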

Compound 3, a percentage reported as inhibition, at one concentration (the size of the read-out at that concentration, not a potency): 50%
Compound 3: middle estimate off by 22 percentage points, on the high side; the range from low to high includes it.
By their numbers in this assay, from the lowest: compound 3; then compound 2; then compound 1.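

In this assay, benzyl in place of phenyl on an oxygen next to a carbonyl group gives a number 25 percentage points lower from compound 2 to compound 3 (beyond the scatter), so the group on that oxygen moves the read-out. Going by these compounds alone, no earlier pair could show this. Within the data shown here, the only earlier step concerned the group on the carbonyl carbon. Read at the carbonyl carbon, benzyloxy in place of dimethylamino gives a number 48 percentage points lower from compound 1 to compound 3 (beyond the scatter), a step printed as large, whereas phenoxy in place of dimethylamino gives the modest a number 23 percentage points lower from compound 1 to compound 2 (beyond the scatter), so among these three compounds the outcome depends on which oxygen-linked group replaces dimethylamino. No measurement at hand bears on why the numbers differ in this way.

As far as these compounds go, it remains open whether a longer chain on the oxygen, such as phenylethyl, would continue the fall seen with benzyl, or whether a small alkyl group such as methyl or a ring carrying nitrogen, such as pyridylmethyl, would behave differently. From the compounds shown here alone, all of these numbers are sizes of inhibition at one concentration, so how the three compounds compare in potency also stays open.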